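Chain-length extension on the glycosylated thiadiazole amide series

The source may report more compounds than this note shows. Statements on the series, on what has been measured and on what is new or still open speak of the compounds shown alone.

Among the compounds with values here, compound 1 `CCCCCCCC(=O)Nc1nnc(S[C@@H]2O[C@H](CO)[C@H](O)[C@H](O)[C@H]2O)s1` is the only member of the series with a numerical result: in a functional assay on SK-OV-3 cells (Homo sapiens) for cytotoxicity, read by MTT assay, with a stated time of 24 h (a higher number here means a weaker inhibitor, a lower number a stronger inhibitor), compound 1 gives 56000 nM, a weak reading. Compound 2 `CCCCCCCCCC(=O)Nc1nnc(S[C@@H]2O[C@H](COC(C)=O)[C@H](OC(C)=O)[C@H](OC(C)=O)[C@H]2OC(C)=O)s1` carries an acetylated sugar and a longer acyl chain; in this assay compound 2 is reported as "not active" (no number reported), without a number. Compound 3 `CCCCCCCC/C=C\CCCCCCCCCCCC(=O)Nc1nnc(S[C@@H]2O[C@H](COC(C)=O)[C@H](OC(C)=O)[C@H](OC(C)=O)[C@H]2OC(C)=O)s1` likewise carries an acetylated sugar and a longer acyl chain; in this assay compound 3 is reported as "not active" (no number reported), without a number. So no measured step exists in this series. Compound 4 `CCCCCCCCCCCCCCCC(=O)Nc1nnc(S[C@@H]2O[C@H](CO)[C@H](O)[C@H](O)[C@H]2O)s1` keeps the free sugar of compound 1 and differs by octyl in place of hydrogen on a saturated chain carbon, seven bonds along the chain from a carbonyl carbon. Within the data shown here, with no measured step to lean on, and the two longer-chain acetylated entries giving no number, the step from compound 1 to compound 4 is expected to be small, at or near the scatter, if anything toward weaker: a 1.3-fold higher number from compound 1 to compound 4 (0.10 log units; within the scatter). In this assay compound 4 is estimated at 70000 nM, between 20000 nM and 200000 nM.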

Compound 4, half-maximal inhibitory concentration: "not active" (no number reported)
For compound 4 the study gives words and no number; the estimate stays without a comparison.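

In this assay, within the data shown here, compound 4 is reported in words only, so no step from compound 1 can be read. The compounds shown leave open how acyl chain length alone changes the reading on either the free or the acetylated sugar. Nothing shown offers an explanation for the result.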